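The source may hold more compounds than are shown below. What is called first, only, known or untested is meant among the compounds shown, and "the series" means these compounds.

Two members of this series have numbers in a functional assay on MCF7 cells (Homo sapiens) for cytotoxicity, read by MTT assay, with a stated time of 48 h; on this read-out higher numbers stand for weaker inhibition and lower numbers for stronger inhibition. Compound 1 `CCCCCCCCCCCCCCNC(=O)[C@@H](NS(=O)(=O)c1ccc(C)cc1)[C@@H](C)O` gives 12900 nM. Compound 2 `CCCCCCCCCCCCCCNC(=O)[C@@H](NS(=O)(=O)c1cccs1)[C@@H](C)O` gives 18700 nM. Within the data shown here, the single step that joins the two, a 1.4-fold higher number from compound 1 to compound 2 (0.16 log units; within the scatter), is the only one on record for exchanging the group on the sulfonyl sulfur. Compound 2 thus stands with the highest of the two numbers, compound 1 being nearest, and the gap between them is within the scatter, so no order can be read from it.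

The next compound, compound 3 `CCCCCCCCCCCCCCNC(=O)[C@@H](NS(=O)(=O)c1ccc2ccccc2c1)[C@@H](C)O`, differs from compound 2 in one place: naphthalen-2-yl in place of thiophen-2-yl on a sulfonyl sulfur. Among the measured compounds shown here, the one measured step that bears on this kind of change is the aryl exchange from compound 1 to compound 2 already given, and it stayed within the scatter. On that basis no step beyond the scatter is expected for compound 3 in this assay, in either direction. For compound 3 the estimated value in this assay is 12000 nM, with a range from 4000 nM to 36000 nM. The step this estimate implies, a 1.6-fold lower number from compound 2 to compound 3 (0.19 log units; within the scatter), is expected to stay within the scatter.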

Compound 3, half-maximal inhibitory concentration: 12200 nM
For compound 3 the middle estimate is 1.0-fold (0.01 log units) below the measured one; the range from low to high includes it.
By their numbers in this assay, from the lowest: compounds 3, 1 and 2 (each within the scatter of the next).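

Notes on the group on a sulfonyl sulfur whose other neighbours are: sulfonamide nitrogen. In this assay, naphthalen-2-yl, with its 2 six-membered aromatic rings of carbon only and 10 heavy atoms, is tolerated much as the smaller groups are: a 1.5-fold lower number from compound 2 to compound 3 (0.19 log units; within the scatter) and a 1.1-fold lower number from compound 1 to compound 3 (0.02 log units; within the scatter) are both printed as within the scatter. Thiophen-2-yl, 4-methylphenyl and naphthalen-2-yl therefore cannot be put in any order here, and across these three compounds, with none going against it, a larger aromatic group on the sulfonyl sulfur leaves the number within the scatter of the others. No measurement at hand speaks to why these numbers stay so close together.

Going by these compounds, all three groups are aromatic and uncharged, so it remains open whether a simple methyl group, or a phenyl ring carrying an amine or a carboxylic acid, on the sulfonyl sulfur would give a step beyond the scatter. Also open, on these data alone, is how the number responds to a shorter chain in place of the long chain that all three compounds share.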